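The compounds below may be only part of what the source reports. "The series", "measured", "known", "first", "only" and "open" are said of these compounds alone.

Compound 2, `CCCS(=O)(=O)Nc1ccc(F)c(C(=O)c2n[nH]c3ncc(-c4ccc(F)cc4)cc23)c1F`, gives 2.1% in an assay for binding affinity to dual specificity mitogen-activated protein kinase kinase 4 (Homo sapiens), read by KINOMEscan, tested at 100 nM (a higher number here means a weaker effect of the compound at the concentration tested, a lower number a stronger effect), the lowest of the two numbers recorded: compound 1, `CCCS(=O)(=O)Nc1ccc(F)c(C(=O)c2n[nH]c3ncc(-c4cccc(Cl)c4)cc23)c1F`, gives 40%, and the step of a number 37.9 percentage points lower from compound 1 to compound 2 (beyond the scatter) is large. Compound 3, `CCCS(=O)(=O)Nc1ccc(F)c(C(=O)c2n[nH]c3ncc(-c4ccc(C)cc4)cc23)c1F`, differs from compound 2 by methyl in place of fluoro on an aromatic carbon. For the measured compounds named here, the only measured step exchanges both the halogen and its place on the ring, so it bears only loosely on a methyl in place of fluoro at the same position; a step within the scatter is expected, worded as a number 2.9 percentage points higher from compound 2 to compound 3 (within the scatter). For compound 3 the expected value in this assay is 5%, within a range of 1% to 25%.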

Compound 3, a percentage reported as activity, at one concentration (the size of the read-out at that concentration, not a potency): 5.4%
For compound 3 the middle estimate is 0.4 percentage points below the measured one; the measured number falls inside the stated range.
By their numbers in this assay, from the lowest: compounds 2 and 3 (each within the scatter of the next); then compound 1.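

At the aromatic carbon para to a large group, methyl and fluoro read alike in this assay: a number 3.3 percentage points higher from compound 2 to compound 3 (within the scatter). The large gap to the 3-chlorophenyl compound therefore does not rest on fluoro alone, as the second 4-substituted ring also shows a number 34.6 percentage points lower from compound 1 to compound 3 (beyond the scatter). Nothing on hand explains this behaviour. On these data alone, whether that gap follows the chlorine or its place on the ring stays open, and a 4-chlorophenyl group would separate the two. As far as these compounds go, how an amine or a carboxylic acid at this position would read also remains open.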